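The source may report more compounds than this note shows. Statements on the series, on what has been measured and on what is new or still open speak of the compounds shown alone.

Measured in a functional assay on SK-N-SH cells (Homo sapiens) for cytotoxicity, read by MTT assay, with a stated time of 48 h; a lower number here means a stronger inhibitor, a higher number a weaker inhibitor:
- Compound 1 `COc1ccc(/C=C/c2cc(OC)c(OC)c(OC)c2-c2ccc(F)c(C)c2)cc1`: 19000 nM
- Compound 2 `COc1cc(/C=C/c2ccccc2)c(-c2ccccc2)c(OC)c1OC`: 63000 nM

Only these two compounds have been measured, and neither is a potent inhibitor in this assay. Compound 2, at 63000 nM, holds the higher of the two numbers, which makes it the weaker inhibitor. Compound 1 stands lower at 19000 nM, and this gap lies beyond the usual scatter.

The next compound, compound 3 `C=C(c1ccccc1)c1cc(OC)c(OC)c(OC)c1-c1ccccc1`, has the same atoms as compound 2, joined differently. It carries 1-phenylethenyl in place of 2-phenylethenyl on an aromatic carbon, ortho to a phenyl group: 1-phenylethenyl in place of 2-phenylethenyl on an aromatic carbon.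

Within the data shown here, no pair of measured compounds shows what this exchange does, so the expectation is a loose one. Among the measured compounds shown here, a small move towards a lower number seems likeliest, with no step clearly beyond the scatter. The expected change is a 1.4-fold lower number from compound 2 to compound 3 (0.15 log units; within the scatter), and a larger move in either direction cannot be ruled out. For compound 3 the estimated value is 45000 nM, with an expected range of 12000 nM to 110000 nM.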

Compound 3, half-maximal inhibitory concentration: 34000 nM
Beside the measured number, compound 3's estimate is 1.3-fold (0.12 log units) above it, within the range that was stated.
By their numbers in this assay, from the lowest: compounds 1, 3 and 2 (each within the scatter of the next, the first and the last beyond it).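

In this assay, putting 1-phenylethenyl in place of 2-phenylethenyl on the aromatic carbon ortho to a phenyl group gives a 1.9-fold lower number from compound 2 to compound 3 (0.27 log units; within the scatter). Among these compounds, this is the first direct reading at this position, and it shows that joining the same atoms differently, with the carbon count, the aromatic ring and the double bond outside it all unchanged, does not move the number beyond the scatter, so the two groups cannot be told apart here. Nothing shown offers a reason for this result, and a step of this size would need none.

Among the compounds shown here, it remains open whether the same exchange would stay within the scatter on the core of compound 1, whose other ring carries methoxy, fluoro and methyl groups, since only the single pair of compound 2 and compound 3 speaks to it. Also open, as far as these compounds go, is what this aromatic carbon would give with a different kind of group, such as an aminomethyl group, a carboxylic acid or a longer chain ending in a phenyl ring, in place of either phenylethenyl group.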